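A few compounds are considered here, and "the series" means these few. Any claim that something is new, unique, unknown or untested is made for them only; others in the source may bear on it.

Measured so far:
compound 1 `N/C(=N\NC(=S)N1CCCCC1)c1ccccn1` — in a functional assay on HeLa cells (Homo sapiens) for cytotoxicity, read by MTT assay, with a stated time of 72 h, tested at 1 uM (on this read-out higher numbers stand for more inhibition of growth at the one concentration tested and lower numbers for less inhibition of growth), compound 1 gives 15.5%
compound 2 `Cc1cccc(/C(N)=N/NC(=S)N2CCOCC2)n1` — in this assay compound 2 gives 25.7%

Compound 2 stands at the top of these two numbers. Its nearest neighbour is compound 1, whose value in this assay lies lower by a gap beyond the usual scatter. Going by the values given here, no single-change step between the two measured compounds is on record, since they differ in more than one place, so their two values can only be set side by side.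

Compound 3 `Cc1cccc(/C(N)=N/NC(=S)N2CCCCC2)n1` is the next member. It differs from compound 2 by piperidin-1-yl in place of morpholin-4-yl on a thiocarbonyl carbon. Compound 1 already carries the same piperidin-1-yl group, but with a different core, so the effect of this exchange on its own cannot be read from the two measured values. He therefore expects for the step from compound 2 to compound 3 in this assay no change beyond the scatter, shown by a number 4.7 percentage points lower from compound 2 to compound 3 (within the scatter). Accordingly, compound 3 is estimated at 21% in this assay, with a range from 8% to 36%.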

Compound 3, percent growth inhibition at one concentration: 27%
Beside the measured number, compound 3's estimate is 6 percentage points below it, and the stated range covers the measured number.
By their numbers in this assay, from the lowest: compound 1; then compounds 2 and 3 (each within the scatter of the next).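

In this assay, putting piperidin-1-yl in place of morpholin-4-yl on a thiocarbonyl carbon gives a number 1.3 percentage points higher from compound 2 to compound 3 (within the scatter), so on this shared core, dropping the ring oxygen of morpholin-4-yl, with the hydrogen-bond acceptor counted for it, leaves the growth inhibition where it was, within the scatter. Going by these compounds alone, compound 3 also provides the first single-change step for the methyl group, since with piperidin-1-yl held constant, methyl in place of hydrogen on an aromatic carbon gives a number 11.5 percentage points higher from compound 1 to compound 3 (beyond the scatter), a modest step. Within the data shown here, of these two steps, only the one at the aromatic carbon lies beyond the scatter, while the one on the thiocarbonyl carbon does not.

The compounds shown leave open whether a ring with a further amine nitrogen, such as piperazin-1-yl, or an open-chain dimethylamino group on the thiocarbonyl carbon would also stay within the scatter of compound 3. They also leave open whether a longer chain such as ethyl, or a methoxy group, on the aromatic carbon would go further than methyl. Nothing measured here explains why either step came out as it did.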